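Aminoamino in place of ethoxy in compound 2

This account rests on a few compounds, and the source may have more. Where it says the series, first, only, none or still open, it means among the compounds named here.

In a functional assay on C8166 cells (Homo sapiens) for antiproliferative activity, read by MTT assay (on this read-out higher numbers stand for lower toxicity in this test and lower numbers for higher toxicity in this test), compound 2 (`CCOC(=O)NNC(=O)c1[nH]c2ccc(Cl)cc2c1S(=O)(=O)c1cc(C)cc(C)c1`) gives > 100 uM, which is a limit of the assay and not a number. Compound 1 (`Cc1cc(C)cc(S(=O)(=O)c2c(C(=O)NNC(C)C)[nH]c3ccc(Cl)cc23)c1`) gives > 100 uM, which is also a limit. These two compounds are joined by a step that the two limits leave unreadable from compound 1 to compound 2, and the limit of > 100 uM in this assay, at which 2 of the 2 values shown sit, sums up all that is known so far. The next change leads to compound 3 (`Cc1cc(C)cc(S(=O)(=O)c2c(C(=O)NNC(=O)NN)[nH]c3ccc(Cl)cc23)c1`), with aminoamino in place of ethoxy on a carbonyl carbon. Among the compounds with values here, no measured step covers this exchange, and the only guide is that compound 2 gives > 100 uM. No step beyond the scatter is therefore expected in this assay, and most likely the reading will again be only a limit. The expected size is a number no higher from compound 2 to compound 3 (the limit leaves the size open). For compound 3 the estimate is 100 uM, with an expected range from 40 uM to 200 uM.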

Compound 3, half-maximal toxic concentration: > 100 uM
Compound 3: no number, only a limit (the forecaster's own chance of this, stated with the estimate: 70%); the middle value sits exactly at the limit.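

In this assay, within the data shown here, compound 3 gives > 100 uM, which is a limit of the assay and not a number, so no step from compound 1 or compound 2 to compound 3 can be read. The compounds shown leave open whether these three differ in toxicity in this test at all, as all that is known is one shared reading: the limit of > 100 uM in this assay, at which 3 of the 3 values shown sit.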